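Replacing the hydroxy on compound 1 with (4-nitrophenyl)amino

The source may hold more compounds than are shown below. What is called first, only, known or untested is meant among the compounds shown, and "the series" means these compounds.

Compound 1 `O=c1cc(/C=N\O)c2c(OCc3ccccc3)cc(OCc3ccccc3)cc2o1` carries two benzyloxy groups on the shared core. In a functional assay, read by spectrophotometry, with a stated time of 5 min (on this read-out lower numbers stand for stronger inhibition and higher numbers for weaker inhibition), compound 1 gives > 2000000 nM, which is a limit of the assay and not a number. Compound 3 `O=c1cc(/C=N\O)c2ccc(OCc3ccccc3)cc2o1` keeps one benzyloxy group; in this assay compound 3 gives > 2000000 nM, again a limit rather than a number. The step that the two limits leave unreadable from compound 1 to compound 3 is therefore not readable, because the limit of > 2000000 nM in this assay, at which 2 of the 3 values shown sit, covers both of these values. Compound 2 `O=c1cc(/C=N\Nc2ccccc2)c2ccc(OCc3ccccc3)cc2o1` carries anilino where compound 3 carries hydroxy, and in this assay compound 2 gives 416000 nM. Going by the values given here, the step of an at least 4.8-fold higher number from compound 2 to compound 3 (0.68 log units; beyond the scatter) is the only measured change that bears on the exchange below.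

Compound 4 `O=c1cc(/C=N\Nc2ccc([N+](=O)[O-])cc2)c2c(OCc3ccccc3)cc(OCc3ccccc3)cc2o1` differs from compound 1 by (4-nitrophenyl)amino in place of hydroxy on a double-bonded nitrogen. Read in reverse, the step of an at least 4.8-fold higher number from compound 2 to compound 3 (0.68 log units; beyond the scatter) points to a lower number when an arylamino group replaces hydroxy on the double-bonded nitrogen. A lower number is therefore expected for compound 4, namely an at least 5.0-fold lower number from compound 1 to compound 4 (0.69 log units; beyond the scatter). The estimate for compound 4 in this assay is 400000 nM, with a range from 100000 nM to 2000000 nM.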

Compound 4, half-maximal inhibitory concentration: 419000 nM
Estimate against measurement, compound 4: 1.0-fold (0.02 log units) below; low and high end bracket the measured number.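

Hydroxy on the double-bonded nitrogen is now exchanged for an arylamino group on a second background: in this assay, the exchange gives an at least 4.7-fold lower number from compound 1 to compound 4 (0.67 log units; beyond the scatter). The earlier readable step came from the core with one benzyloxy group, whereas this one comes from the core with two, so a lower number with an arylamino group is no longer confined to a single background. Only a minimum can be given for this step, because compound 1 stands at a limit: the limit of > 2000000 nM in this assay, at which 2 of the 4 values shown sit.

No pair shown separates (4-nitrophenyl)amino from plain anilino on one core, and the step for the second benzyloxy group cannot be read. Also open, as far as these compounds go, is how an alkylamino group, or an aryl ring carrying an amine or a carboxylic acid in place of nitro, would read at this position.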